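The source may hold more compounds than are shown below. What is called first, only, known or untested is meant among the compounds shown, and "the series" means these compounds.

Measured so far:
compound 1, `CCc1ccc(N(CC(C)C)S(=O)(=O)c2ccc3c(c2)C(O)CC(C2CCN(S(C)(=O)=O)CC2)O3)cc1`: 3.22
compound 2, `CC(C)CN(Cc1ccccc1C(F)(F)F)S(=O)(=O)c1ccc2c(c1)C(O)CC(C1CCOCC1)O2`: 4.23
compound 3, `O=S(=O)(c1ccc2c(c1)C(O)CC(C1CCOCC1)O2)N1CCCC1c1ccccc1C(F)(F)F`: 3.41

In a physicochemical assay for lipophilicity, at pH 7.4 (on this read-out lower numbers stand for lower lipophilicity and higher numbers for higher lipophilicity), compound 2 stands highest of the three numbers; compound 3 is nearest to it and compound 1 furthest, and both of those gaps lie beyond the usual scatter. Compound 4, `CC(C)CN(c1ccc(F)cc1)S(=O)(=O)c1ccc2c(c1)C(O)CC(C1CCOCC1)O2`, has not yet been measured in this assay. It differs from compound 2 in one place: 4-fluorophenyl in place of 2-(trifluoromethyl)benzyl on a sulfonamide nitrogen. With a smaller group entering, the number in this assay is expected to fall rather than rise, by a step clearly beyond the scatter, since the group that leaves is larger by four heavy atoms and carries three fluorines against one. The expected step is a number 0.93 log units lower from compound 2 to compound 4 (beyond the scatter), a drop. For compound 4 the estimate in this assay is 3.3, in the range 2.8 to 3.8.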

Compound 4, distribution coefficient: 3.39
Compound 4: the middle estimate sits 0.09 log units below what was measured; measured number inside the range.
By their numbers in this assay, from the lowest: compounds 1, 4 and 3 (each within the scatter of the next); then compound 2.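

In this assay, the swap of 2-(trifluoromethyl)benzyl for 4-fluorophenyl on the sulfonamide nitrogen gives a number 0.84 log units lower from compound 2 to compound 4 (beyond the scatter) with the rest of the molecule unchanged. This single-place comparison shows that the group at this position can by itself shift the read-out beyond the scatter. Nothing available explains the size of this step. This one pair cannot separate the loss of the trifluoromethyl group from the change from benzyl to phenyl. As far as these compounds go, how a group carrying an amine or a carboxylic acid would read at this position also remains open.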